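Moving the methyl on the aryl triazole: compounds 3 to 4

The compounds below may be only part of what the source reports. "The series", "measured", "known", "first", "only" and "open" are said of these compounds alone.

Compound 1 `Cc1cccc(-n2cc(-c3ccccc3NS(=O)(=O)c3c[nH]c(=O)[nH]c3=O)nn2)c1` gives 23700 nM in an ADME assay on GES1 cells (Homo sapiens) for cytotoxicity, read by MTT assay, with a stated time of 24 h; a lower number here means that less compound is tolerated, a higher number that more compound is tolerated.
Compound 2 `O=c1[nH]cc(S(=O)(=O)Nc2cccc(-c3cn(-c4ccccc4)nn3)c2)c(=O)[nH]1` gives 22500 nM in this assay.
Compound 3 `Cc1ccccc1-n1cc(-c2cccc(NS(=O)(=O)c3c[nH]c(=O)[nH]c3=O)c2)nn1` gives 21500 nM in this assay.

The three measured compounds sit close together. Compound 3 gives the lowest of the three numbers, yet its separation from compound 2 and from compound 1 falls within the scatter, so no order among them can be read. Among the measured compounds shown here, the only single-place step measured is a 1.0-fold lower number from compound 2 to compound 3 (0.02 log units; within the scatter), which shows that adding a methyl to the aromatic ring leaves the number where it was.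

Compound 4 `Cc1cccc(-n2cc(-c3cccc(NS(=O)(=O)c4c[nH]c(=O)[nH]c4=O)c3)nn2)c1` differs from compound 3 by 3-methylphenyl in place of 2-methylphenyl on an aromatic nitrogen. This moves the methyl around the ring rather than adding or removing it. Compound 1, which also carries a 3-methylphenyl group, gives 23700 nM, and the step from compound 2 to compound 3 was flat, so no movement beyond the scatter is expected here either. Compound 4 is therefore estimated at 22500 nM, with a range from 12000 nM to 42000 nM, a step of a 1.0-fold higher number from compound 3 to compound 4 (0.02 log units; within the scatter) expected to stay within the scatter.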

Compound 4, half-maximal cytotoxic concentration: 18500 nM
Compound 4: the middle estimate sits 1.2-fold (0.09 log units) above what was measured; measured number inside the range.
By their numbers in this assay, from the lowest: compounds 4, 3, 2 and 1 (each within the scatter of the next).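

Moving the methyl on the phenyl group carried by the aromatic nitrogen, from 2-methylphenyl to 3-methylphenyl, gives a 1.2-fold lower number from compound 3 to compound 4 (0.07 log units; within the scatter) in this assay and so does not separate the two placements of the methyl. Measured against the phenyl group without a methyl, the 3-methylphenyl group gives a 1.2-fold lower number from compound 2 to compound 4 (0.09 log units; within the scatter) and so joins the 2-methylphenyl group in leaving the number where it was. Across these compounds, then, neither placement of the methyl on this ring shifts the number beyond the scatter, and no measurement shown here speaks to why.

From the compounds shown here alone, what stays open is whether a group other than methyl on this ring, such as an amine, a carboxylic acid or a longer chain, would move the number beyond the scatter.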